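The source may report more compounds than this note shows. Statements on the series, on what has been measured and on what is new or still open speak of the compounds shown alone.

Compound 1 `Oc1ccc(CNc2cc(C(F)(F)F)cc3[nH]ncc23)cc1`: 37%
Compound 2 `FC(F)(F)c1cc(NC[C@H]2CCCN2)c2cn[nH]c2c1`: 34%

Both measured compounds were tested in an assay for inhibition of Indoleamine 2,3-dioxygenase 1 (Homo sapiens), with stated times of 10 min and 60 min, tested at 10 uM (on this read-out lower numbers stand for a weaker effect and higher numbers for a stronger effect at the one concentration tested), where compound 1 gives 37% and compound 2 gives 34%. On these two numbers compound 1 is separated from compound 2 only by a number 3 percentage points lower from compound 1 to compound 2 (within the scatter), a gap within the scatter, so the two cannot be told apart; that step swaps pyrrolidin-2-yl for 4-hydroxyphenyl on a saturated chain carbon bound to a nitrogen on an aromatic ring.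

Compound 3 `Oc1ccc(CNc2cc(C(F)(F)F)cc3[nH]ncc23)c(Cl)c1` is not yet measured. It differs from compound 1 by chloro in place of hydrogen on an aromatic carbon, the new atom sitting ortho to a large group and meta to the hydroxy group. Within the data shown here, no measured step resembles this: the single step on record exchanges the whole 4-hydroxyphenyl group rather than one hydrogen on it, so it gives no guide to the direction or size of the effect. Without such a guide, the expected step is a number 3 percentage points higher from compound 1 to compound 3 (within the scatter), that is, nothing beyond the scatter. Compound 3 is therefore estimated at 40%, with a likely range from 20% to 62%.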

Compound 3, a percentage reported as inhibition, at one concentration (the size of the read-out at that concentration, not a potency): 83%
Estimate against measurement, compound 3: 43 percentage points below; measured number outside the range, above it.
By their numbers in this assay, from the lowest: compounds 2 and 1 (each within the scatter of the next); then compound 3.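

In this assay, replacing one hydrogen with chloro, on the aromatic carbon ortho to a large group and meta to a hydroxy group, gives a number 46 percentage points higher from compound 1 to compound 3 (beyond the scatter), so this position on the ring responds strongly to a change of a single heavy atom. The earlier step, a number 3 percentage points lower from compound 1 to compound 2 (within the scatter), exchanged the whole 4-hydroxyphenyl group and could not show this: it left the two numbers indistinguishable and said nothing about any single carbon on that ring. The new step shows that the entering chloro, which counts no hydrogen-bond donors or acceptors and no net charge, is enough to move the read-out far beyond the scatter, but nothing measured here explains why this happens.

With only this one substitution shown, it remains open whether the gain belongs to chloro itself or would also appear with fluoro, bromo, methyl or methoxy on the same carbon, and whether chloro on another carbon of the ring would do the same. As far as these compounds go, the read-out is also the size of the effect at one concentration rather than a potency, so how much stronger compound 3 is as an inhibitor remains open too.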